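Swapping a side chain for formyl in compound 4

The source may hold more compounds than are shown below. What is called first, only, known or untested is meant among the compounds shown, and "the series" means these compounds.

Measured in a toxicity assay on HeLa cells (Homo sapiens) for cytotoxicity, read by MTT assay, with a stated time of 48 h; on this read-out lower numbers stand for stronger inhibition and higher numbers for weaker inhibition:
- compound 1 `N#C/C(=C\c1ccc(-c2ccc(-c3ccc(N(c4ccccc4)c4ccccc4)cc3)s2)s1)C(=O)O`: 21900 nM
- compound 2 `CC(C)(C)OC(=O)/C(C#N)=C/c1ccc(-c2ccc(-c3ccc(N(c4ccccc4)c4ccccc4)cc3)s2)s1`: > 100000 nM, a limit of the assay and not a number
- compound 3 `N#C/C(=C\c1ccc(-c2ccc(-c3ccc(N(c4ccccc4)c4ccccc4)cc3)s2)s1)C(N)=O`: 63100 nM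

Compound 3 has the higher of the two exact numbers, with a 2.9-fold higher number from compound 1 to compound 3 (0.46 log units; beyond the scatter). Compound 4 `O=Cc1ccc(-c2ccc(-c3ccc(N(c4ccccc4)c4ccccc4)cc3)s2)s1` has formyl in place of 2-carbamoyl-2-cyanoethenyl on an aromatic carbon. The nearest evidence comes from smaller changes that start at compound 1, namely a 2.9-fold higher number from compound 1 to compound 3 (0.46 log units; beyond the scatter) and an at least 4.5-fold higher number from compound 1 to compound 2 (0.65 log units; beyond the scatter). Neither removes the whole side chain, so the expectation in this assay stays loose. The expected change is a 1.1-fold lower number from compound 3 to compound 4 (0.02 log units; within the scatter), with no clear shift beyond the scatter. For compound 4 the estimated value is 60000 nM, with an expected range from 20000 nM to 150000 nM.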

Compound 4, half-maximal inhibitory concentration: 88900 nM
For compound 4 the middle estimate is 1.5-fold (0.17 log units) below the measured one; low and high end bracket the measured number.
By their numbers in this assay, from the lowest: compound 1; then compounds 3 and 4 (each within the scatter of the next). At a limit, above all of these: compound 2.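

Replacing the whole side chain with formyl, on the aromatic carbon next to the ring sulfur, gives a 1.4-fold higher number from compound 3 to compound 4 (0.15 log units; within the scatter) and leaves the two numbers within the scatter of each other. The same swap from the 2-carboxy-2-cyanoethenyl side chain gives a 4.1-fold higher number from compound 1 to compound 4 (0.61 log units; beyond the scatter), so among the exact numbers only compound 1 stands apart. Compound 2 sits at a limit of the assay and not at a number: the limit of > 100000 nM in this assay, at which 1 of the 4 values shown sits.

Measured against that limit, the swap from the 2-cyano-2-(tert-butoxycarbonyl)ethenyl side chain gives an at least 1.1-fold lower number from compound 2 to compound 4 (0.05 log units; that floor lies within the scatter) and sets no firm order.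

Going by these compounds, whether an amine or a hydroxymethyl group at this position would give a lower number than compound 1 stays open.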